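Chloro on the benzyl ring of the sulfonamide series

A few compounds are considered here, and "the series" means these few. Any claim that something is new, unique, unknown or untested is made for them only; others in the source may bear on it.

Compound 3 `O=S(=O)(NCCCNCc1ccccc1)c1cc(C(F)(F)F)cc(C(F)(F)F)c1` gives 16000 nM in a functional assay on PANC-1 cells (Homo sapiens) for inhibition, read by MTT assay, with a stated time of 72 h (a lower number here means a stronger inhibitor of growth, a higher number a weaker inhibitor of growth), the highest number of the three shown; its nearest neighbour is compound 1 `O=S(=O)(NCCCNCc1ccccc1Cl)c1cc(C(F)(F)F)cc(C(F)(F)F)c1` with 15000 nM, and compound 2 `O=S(=O)(NCCCNCc1ccc(Cl)c(C(F)(F)F)c1)c1cc(C(F)(F)F)cc(C(F)(F)F)c1` gives 10000 nM, both differences sitting within the scatter. Compound 4 `O=S(=O)(NCCCNCc1cccc(Cl)c1)c1cc(C(F)(F)F)cc(C(F)(F)F)c1` differs from compound 3 by chloro in place of hydrogen on an aromatic carbon. Two measured changes bear on this: a 1.1-fold higher number from compound 1 to compound 3 (0.03 log units; within the scatter) and a 1.6-fold higher number from compound 2 to compound 3 (0.20 log units; within the scatter), neither beyond the scatter. Among the measured compounds shown here, a chloro entering this ring has therefore not moved this assay so far, and no step beyond the scatter is expected in either direction. For compound 4 the estimate in this assay is 13000 nM, ranging from 6000 nM to 30000 nM, which means an expected step of a 1.2-fold lower number from compound 3 to compound 4 (0.09 log units; within the scatter).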

Compound 4, concentration for 50% growth inhibition: 12000 nM
The estimate for compound 4 lay 1.1-fold (0.03 log units) above the measured number; the measured number falls inside the stated range.
By their numbers in this assay, from the lowest: compounds 2, 4, 1 and 3 (each within the scatter of the next).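

With chloro on an aromatic carbon meta to a large group, this assay gives a 1.3-fold lower number from compound 3 to compound 4 (0.12 log units; within the scatter) and so shows that this position also leaves the number within the scatter of the unsubstituted benzyl. The readings a 1.3-fold lower number from compound 1 to compound 4 (0.10 log units; within the scatter) and a 1.2-fold higher number from compound 2 to compound 4 (0.08 log units; within the scatter) add that 3-chlorophenyl cannot be separated from 2-chlorophenyl or 4-chloro-3-(trifluoromethyl)phenyl in this series. Nothing available explains why these steps stay so small. Still open, on these data alone, is whether an amine or a carboxylic acid on this ring would give a step beyond the scatter. As far as these compounds go, a longer chain in the shared core is equally open.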